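This account rests on a few compounds, and the source may have more. Where it says the series, first, only, none or still open, it means among the compounds named here.

Of the compounds shown here, three built on one shared core have been measured in a functional assay on KYSE-450 cells (Homo sapiens) for inhibition, read by CCK-8 assay, with a stated time of 48 h; a lower number here means a stronger inhibitor, a higher number a weaker inhibitor. Compound 1 `COc1ccc(CN(C(=O)CSC(=S)N2CCN(C(=O)OC(C)(C)C)CC2)c2cc(OC)c(OC)c(OC)c2)cc1` gives 250 nM. Compound 2 `COc1ccc(CN(C(=O)CSC(=S)N2CCN(C(=O)OC(C)(C)C)CC2)c2cc(OC)c(OC)c(OC)c2)cc1C`, with methyl in place of hydrogen on an aromatic carbon, stands at > 20000 nM, which is a limit of the assay and not a number. Compound 3 `COc1ccc(CN(C(=O)CSC(=S)N2CCN(C(=O)OC(C)(C)C)CC2)c2cc(OC)c(OC)c(OC)c2)cc1O`, with hydroxy in place of that hydrogen, gives 76 nM. This is the lowest number of the three, and the nearest value belongs to compound 1, with a 3.3-fold lower number from compound 1 to compound 3 (0.52 log units; beyond the scatter), a modest step beyond the scatter.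

Compound 4 `COc1ccc(CN(C(=O)CSC(=S)N2CCN(C(C)=O)CC2)c2cc(OC)c(OC)c(OC)c2)cc1O` differs from compound 3 in one place: methyl in place of tert-butoxy on a carbonyl carbon. In other words, tert-butoxycarbonyl becomes acetyl. Among the measured compounds shown here, no measured step touches this place, since all of them changed an aromatic carbon elsewhere, so they bear on it only indirectly. They show that one small change can matter a great deal, as compound 2 does with an at least 80-fold higher number from compound 1 to compound 2 (1.90 log units; beyond the scatter), or only modestly, as compound 3 does with a 3.3-fold lower number from compound 1 to compound 3 (0.52 log units; beyond the scatter). The direction is therefore a cautious guess, and a modest move towards a weaker inhibitor in this assay is expected, an estimated 2.6-fold higher number from compound 3 to compound 4 (0.42 log units; beyond the scatter). The estimated value for compound 4 is 200 nM, with an expected range from 40 nM to 2000 nM.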

Compound 4, half-maximal inhibitory concentration: 210 nM
The estimate for compound 4 lay 1.1-fold (0.02 log units) below the measured number; the measured number falls inside the stated range.
By their numbers in this assay, from the lowest: compound 3; then compounds 4 and 1 (each within the scatter of the next). At a limit, above all of these: compound 2.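

Among the compounds shown here, this is the first measured change away from the aromatic carbons. On a carbonyl carbon whose other neighbours are an amide-type nitrogen in a ring, tert-butoxycarbonyl becomes acetyl, and this assay records a modest loss, a 2.8-fold higher number from compound 3 to compound 4 (0.44 log units; beyond the scatter), so this position does respond to what sits on it. Even so, replacing tert-butoxy, with its 5 heavy atoms, by methyl, with 1, does not cause a collapse of the kind seen with the methyl on the aromatic carbon, and compound 4 still gives 210 nM, although no measurement shown here bears on why this step has the size it has.

On these data alone, two compounds at this position cannot show whether the trend follows the size of the group, so it remains open how a free amine, a longer chain such as propionyl, or a benzoyl group in place of acetyl would behave. As far as these compounds go, it also remains open whether the effect of exchanging tert-butoxycarbonyl for acetyl would be the same size with hydrogen or methyl in place of the hydroxy group on the aromatic carbon.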